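This account rests on a few compounds, and the source may have more. Where it says the series, first, only, none or still open, it means among the compounds named here.

Three compounds share one core and differ only in the group on the fused ring at the end of the chain. Compound 1 `Cc1ccc2nc(NCCCCOc3cc(O)c4c(=O)cc(-c5ccccc5)oc4c3)sc2c1` carries a methyl there, and in an ADME assay on MDCK cells (Canis lupus familiaris) for cytotoxicity, read by sulforhodamine B assay, with a stated time of 48 h (a lower number here means a stronger inhibitor, a higher number a weaker inhibitor), compound 1 gives 294 ug/mL. Compound 2 `O=c1cc(-c2ccccc2)oc2cc(OCCCCNc3nc4ccc([N+](=O)[O-])cc4s3)cc(O)c12` carries a nitro; in this assay compound 2 gives 310 ug/mL. Compound 3 `O=c1cc(-c2ccccc2)oc2cc(OCCCCNc3nc4ccc(I)cc4s3)cc(O)c12` carries an iodo, and in this assay compound 3 gives 298 ug/mL. The three numbers sit close together: the step of a 1.1-fold higher number from compound 1 to compound 2 (0.02 log units; within the scatter), the step of a 1.0-fold higher number from compound 1 to compound 3 (0.01 log units; within the scatter) and the step of a 1.0-fold lower number from compound 2 to compound 3 (0.02 log units; within the scatter) all lie within the scatter, so compound 3 stands neither apart from compound 1 nor from compound 2.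

Compound 4 `O=c1cc(-c2ccccc2)oc2cc(OCCCCNc3nc4ccc(C(F)(F)F)cc4s3)cc(O)c12` is the next member. The change from compound 3 is trifluoromethyl in place of iodo on an aromatic carbon. Every step seen so far at this position, methyl to nitro, methyl to iodo and nitro to iodo, left this assay unmoved beyond the scatter, so no step beyond the scatter is expected here either. Compound 4 is therefore expected to give 300 ug/mL in this assay, between 200 ug/mL and 450 ug/mL, a step of a 1.0-fold higher number from compound 3 to compound 4 (0.00 log units; within the scatter) that is expected to be flat.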

Compound 4, half-maximal inhibitory concentration: 278 ug/mL
Estimate against measurement, compound 4: 1.1-fold (0.03 log units) above; measured number inside the range.
By their numbers in this assay, from the lowest: compounds 4, 1, 3 and 2 (each within the scatter of the next).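

In this assay trifluoromethyl, four heavy atoms entering where one iodine leaves, gives a 1.1-fold lower number from compound 3 to compound 4 (0.03 log units; within the scatter) and gives a 1.1-fold lower number from compound 2 to compound 4 (0.05 log units; within the scatter) against nitro and a 1.1-fold lower number from compound 1 to compound 4 (0.02 log units; within the scatter) against methyl on the same aromatic carbon. All three steps lie within the scatter, so a group of four heavy atoms joins methyl, nitro and iodo at this position, and the four compounds cannot be told apart in this assay by this group. Nothing available gives a reason for this flat result.

As far as these compounds go, it remains open whether an amine or a carboxylic acid on this aromatic carbon would also stay within the scatter. Also open, from the compounds shown here alone, is whether a longer chain would change the number in this assay at all, as the chain is the same in all four compounds.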